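The compounds below may be only part of what the source reports. "The series", "measured", "known", "first", "only" and "open" are said of these compounds alone.

In a physicochemical assay for solubility, read by LC-MS, in phosphate buffer, with a stated time of 24 h, at pH 6.8 (a higher number here means a more soluble compound, a lower number a less soluble compound), compound 1 (`C[C@@H](c1ccc(NC(=O)N2CC(c3cccnc3)C2)cc1)N1Cc2ccccc2C1=O`) gives 130000 nM, and compound 2 (`C[C@H](NC(=O)c1cccc(F)c1)c1ccc(NC(=O)N2CC(c3cccnc3)C2)cc1`) gives 11000 nM, the lower of the two numbers. Going by the values given here, only one measured step bears on what follows, a 12-fold lower number from compound 1 to compound 2 (1.07 log units; beyond the scatter). It is large, and compound 2 is the one carrying the 3-fluorophenyl. Compound 3 (`C[C@H](NC(=O)c1ncccn1)c1ccc(NC(=O)N2CC(c3cccnc3)C2)cc1`) has pyrimidin-2-yl in place of 3-fluorophenyl on a carbonyl carbon. Among the compounds with values here, this exact swap has no measured precedent, so that step is only a rough guide. The expected change is upward and of moderate size, a 5.5-fold higher number from compound 2 to compound 3 (0.74 log units; beyond the scatter). The estimated value for compound 3 is 60000 nM, within an expected range from 20000 nM to 180000 nM.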

Compound 3, solubility: 930000 nM
Compound 3: the middle estimate sits 16-fold (1.19 log units) below what was measured; the measured number lies above the stated range.
By their numbers in this assay, from the lowest: compound 2; then compound 1; then compound 3.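

In this assay, the group on the carbonyl carbon has a large effect: pyrimidin-2-yl in place of 3-fluorophenyl gives an 85-fold higher number from compound 2 to compound 3 (1.93 log units; beyond the scatter), so this one ring swap outweighs the earlier drop. The overall change gives a 7.2-fold higher number from compound 1 to compound 3 (0.85 log units; beyond the scatter), which places an amide of this type above compound 1, whereas compound 2 lay below it. Nothing measured here explains the rise.

The compounds shown do not separate the effect of the two ring nitrogens from that of losing the fluorine. A plain phenyl or a pyridin-2-yl on the same carbonyl carbon would bear on that question.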